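Lengthening the chain toward a cytotoxic stomach-cell lead

A few compounds are considered here, and "the series" means these few. Any claim that something is new, unique, unknown or untested is made for them only; others in the source may bear on it.

Compound 1 `N#C/N=C1\N(CCCCCOc2ccc(Cl)cc2)C(=O)CN1c1ccncc1` carries a cyanoimino ring core and a chain ending in a 4-chlorophenoxy group. In a functional assay on NUGC cells (stomach, Homo sapiens) for cytotoxicity (a higher number here means a weaker inhibitor, a lower number a stronger inhibitor), compound 1 gives 2760 nM. Compound 2 `N#C/N=C1\N(CCCCCCOc2ccc(Cl)cc2)C(=O)CN1c1ccncc1` differs by one change, ((4-chlorophenoxy)methyl in place of 4-chlorophenoxy on a saturated chain carbon, five bonds along the chain from an amide-type nitrogen in a ring), and in this assay compound 2 gives 386 nM; the step of a 7.2-fold lower number from compound 1 to compound 2 (0.85 log units; beyond the scatter) is clearly beyond the usual scatter. Compound 3 `N#C/N=C1\N(CCCCCCOc2ccc(Cl)cc2)C(=O)CCN1c1ccncc1` has a core that differs from that of compound 1 in a way that is not broken down here, while keeping the chain of compound 2. In this assay, among the compounds with values here, compound 3 gives 288 nM, the lowest of the three numbers so far, though its gap to compound 2 is within the scatter, so the two cannot be ranked against each other.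

Compound 4 `N#C/N=C1\N(CCCCCCCOc2ccc(Cl)cc2)C(=O)CCN1c1ccncc1` is built from compound 3 by (4-chlorophenoxy)methyl in place of 4-chlorophenoxy on a saturated chain carbon, six bonds along the chain from an amide-type nitrogen in a ring. This is the same kind of change that led from compound 1 to compound 2, but the place is not identical: there it sat five bonds along the chain from the amide-type nitrogen in a ring, here six bonds along. Since the step of a 7.2-fold lower number from compound 1 to compound 2 (0.85 log units; beyond the scatter) was already taken on the way to compound 3, a further gain is expected to be smaller, and the step from compound 3 to compound 4 is estimated at a 1.6-fold lower number from compound 3 to compound 4 (0.20 log units; within the scatter). Compound 4 is therefore expected to give about 180 nM in this assay, likely between 70 nM and 450 nM.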

Compound 4, half-maximal inhibitory concentration: 1100 nM
The estimate for compound 4 lay 6.1-fold (0.79 log units) below the measured number, and the stated range ends below it.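

In this assay the same change now gives a 3.8-fold higher number from compound 3 to compound 4 (0.58 log units; beyond the scatter), so the gain seen on the core of compound 1 does not carry over to the core of compound 3, and one more chain carbon here goes with a weaker result. Set side by side, the two steps run in opposite directions, and the gap between them is larger than chance scatter would explain: the same change on two cores in this assay, a 7.2-fold lower number (0.85 log units; beyond the scatter) from compound 1 to compound 2 and a 3.8-fold higher number (0.58 log units; beyond the scatter) from compound 3 to compound 4, 27-fold (1.44 log units) apart, beyond the scatter of two such steps. This does not show that the core alone decides the outcome: the change sits five bonds along the chain from the amide-type nitrogen in the first step and six bonds along in the second, so core and place vary together, and one pair on each core cannot separate them.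

The compounds shown leave open how the chain of compound 4 would behave on the core of compound 1, which is the pairing that would tell the effect of the core from the effect of chain length. They also leave open whether a longer chain still, or an amine or a carboxylic acid in place of the 4-chlorophenoxy group, would hold the numbers seen for compound 2 and compound 3.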